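A few compounds are considered here, and "the series" means these few. Any claim that something is new, unique, unknown or untested is made for them only; others in the source may bear on it.

Measured so far:
- compound 1, `CC(C)c1noc(N2CCN(C(=O)[C@@H]3CCCN(S(=O)(=O)c4ccc(S(=O)(=O)C(C)C)cc4)C3)CC2)n1`: > 1 h
- compound 2, `CCN(CC)S(=O)(=O)c1ccc(S(=O)(=O)N2CCC[C@@H](C(=O)NC3COC3)C2)cc1`: 0.308 h
- compound 3, `CCC(CC)S(=O)(=O)c1ccc(S(=O)(=O)N2CCC[C@@H](C(=O)N3CCN(c4nc(C(C)C)no4)CC3)C2)cc1`: 0.0422 h

In an ADME assay on microsomes from liver (Homo sapiens) for metabolic stability, read by LC-MS, with a stated time of 60 min, tested at 10 uM (on this read-out higher numbers stand for a longer-lived compound and lower numbers for a shorter-lived compound), compound 1 reaches only a limit of the assay, (the limit of > 1 h in this assay, at which 1 of the 3 values shown sits), so no exact number is known for it. Compound 3 stands lowest of the two numbers given; its nearest neighbour is compound 2, whose value is 0.308 h. Within the data shown here, the one step measured in one place, an at least 23-fold lower number from compound 1 to compound 3 (1.37 log units; beyond the scatter), is large.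

Compound 4, `CCN(CC)C(=O)c1ccc(S(=O)(=O)N2CCC[C@@H](C(=O)N3CCN(c4nc(C(C)C)no4)CC3)C2)cc1`, has not yet been measured. Among the measured compounds shown here, its only difference from compound 3 is diethylcarbamoyl in place of (pentan-3-yl)sulfonyl on an aromatic carbon. For the measured compounds named here, no measured step exchanges these two groups directly, so the step from compound 1 to compound 3 bears on it only loosely: altering the group on the sulfonyl sulfur changed the half-life a great deal there, and removing the (pentan-3-yl)sulfonyl group entirely may likewise move the value, most plausibly upward, though the size is uncertain. The expected step is a 7.1-fold higher number from compound 3 to compound 4 (0.85 log units; beyond the scatter). Compound 4 is therefore estimated to give 0.3 h in this assay, within a range of 0.08 h to 1 h.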

Compound 4, half-life: 0.213 h
The estimate for compound 4 lay 1.4-fold (0.15 log units) above the measured number; the measured number falls inside the stated range.
By their numbers in this assay, from the lowest: compound 3; then compounds 4 and 2 (each within the scatter of the next). At a limit, above all of these: compound 1.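

Among these compounds, at this aromatic carbon, the earlier compounds showed only a change of the group on the sulfonyl sulfur, whereas here the sulfonyl itself gives way to a carbonyl. In this assay, replacing (pentan-3-yl)sulfonyl with diethylcarbamoyl gives a 5.0-fold higher number from compound 3 to compound 4 (0.70 log units; beyond the scatter), so a group without a sulfonyl can do better than one of the sulfonyl groups, but replacing isopropylsulfonyl with it gives an at least 4.6-fold lower number from compound 1 to compound 4 (0.67 log units; beyond the scatter), placing diethylcarbamoyl between the two sulfonyl groups. The value of compound 1 is a limit and not a number: the limit of > 1 h in this assay, at which 1 of the 4 values shown sits.

On these data alone, it remains open whether the half-life follows the exchange of sulfonyl for carbonyl or the alkyl groups attached, and an isopropyl ketone on the shared core would help separate the two. As far as these compounds go, how a small group such as a nitrile would fare at this carbon is also open.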